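Bromo in Place of Trifluoromethyl: Cytotoxicity on Vero Cells

The compounds below may be only part of what the source reports. "The series", "measured", "known", "first", "only" and "open" are said of these compounds alone.

Compound 1, `FC(F)(F)c1ccc(NCc2cn(-c3ccccc3)nc2-c2ccc(Br)cc2)cc1`, in an ADME assay on Vero 76 cells (Chlorocebus sabaeus) for cytotoxicity, read by MTT assay, with a stated time of 96 h (on this read-out higher numbers stand for lower toxicity in this test and lower numbers for higher toxicity in this test), gives 28000 nM.
Compound 2, `FC(F)(F)c1ccc(-c2nn(-c3ccccc3)cc2CNc2ccc(Br)cc2)cc1`, in this assay gives 17000 nM.
Compound 3, `Clc1ccc(NCc2cn(-c3ccccc3)nc2-c2ccc(Br)cc2)cc1`, in this assay gives 43000 nM; > 100000 nM (2 entries).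

Among the two plain numbers, compound 2 has the lower one, and compound 1 sits within the usual scatter of it. Compound 4, `Brc1ccc(NCc2cn(-c3ccccc3)nc2-c2ccc(Br)cc2)cc1`, has not been measured; it differs from compound 2 by bromo in place of trifluoromethyl on an aromatic carbon. Within the data shown here, no measured pair differs in just this way, so no step of this kind can be quoted. Compound 4 is expected to give about 30000 nM, in a range from 12000 nM to 90000 nM, which means an expected step of a 1.8-fold higher number from compound 2 to compound 4 (0.25 log units; within the scatter), little beyond the scatter.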

Compound 4, half-maximal cytotoxic concentration: 88000 nM
Compound 4: middle estimate off by 2.9-fold (0.47 log units), on the low side; measured number inside the range.
By their numbers in this assay, from the lowest: compounds 2 and 1 (each within the scatter of the next); then compound 4.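

In this assay, bromo in place of trifluoromethyl gives a higher number, meaning lower toxicity in this test, at two different places on the shared core: a 5.2-fold higher number from compound 2 to compound 4 (0.71 log units; beyond the scatter) and a 3.1-fold higher number from compound 1 to compound 4 (0.50 log units; beyond the scatter). Each step lies beyond the scatter, so the change from 4-(trifluoromethyl)phenyl to 4-bromophenyl has the same direction at both places. Readings at this high end need caution, since two entries of compound 3 are limits of the assay: the several entries of compound 3 in this assay, 43000 nM; > 100000 nM (2 entries)

The compounds shown do not tell how a nitrile, a methoxy group or an amine on this aromatic carbon would read. They also give no reason for either step.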